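The compounds below may be only part of what the source reports. "The series", "measured", "known", "first", "only" and "open" are said of these compounds alone.

Working notes on the series. The read-out followed here is an ADME assay on the whole organism (Mus musculus, strain CD1) for pharmacokinetics, read by LC-MS, with a stated time of 24 h, at a dose of 5 mg/kg by the oral route; on this read-out lower numbers stand for lower oral bioavailability and higher numbers for higher oral bioavailability. Compound 1 `O=C(O)Cn1nc(Cc2nc3cc(Cl)c(OCC(F)F)cc3[nH]2)c2ccccc2c1=O` gives 4% in this assay. Compound 2 `CCC(C(=O)O)c1nn(Cc2cn3cc(OCC4CC4)c(Cl)cc3n2)c2ccccc2c1=O` gives 18% in this assay. Compound 3 `C[C@H](C(=O)O)n1nc(Cn2cc3cc(OCC4CC4)c(Cl)cc3n2)c2ccccc2c1=O` gives 60% in this assay. Among these three numbers compound 2 stands second highest: its nearest neighbour is compound 1, whose number lies lower by a gap beyond the scatter, and the furthest is compound 3, whose number lies higher by a gap also beyond the scatter.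

Compound 4 `C[C@H](C(=O)O)c1nn(Cc2cn3cc(OCC4CC4)c(Cl)cc3n2)c2ccccc2c1=O` is not yet measured. Relative to compound 2 the change is 1-carboxyethyl in place of 1-carboxypropyl on an aromatic carbon. Going by the values given here, no step between measured compounds isolates this change, so its effect has to be judged from the spread of compounds 1 to 3 alone, which runs from the number of compound 1 up to the number of compound 3. A modest upward step from compound 2 is expected, though one that stays within the scatter would not be surprising. The step of a number 12 percentage points higher from compound 2 to compound 4 (beyond the scatter) is the estimated size of this move. For compound 4 the estimate in this assay is 30%, with a range from 10% to 60%.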

Compound 4, oral bioavailability: 28%
Beside the measured number, compound 4's estimate is 2 percentage points above it; the measured number falls inside the stated range.
By their numbers in this assay, from the lowest: compound 1; then compounds 2 and 4 (each within the scatter of the next); then compound 3.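

In this assay, this pair gives the series its first comparison that differs in one place: 1-carboxyethyl in place of 1-carboxypropyl on the aromatic carbon next to the ring nitrogen is a number 10 percentage points higher from compound 2 to compound 4 (within the scatter). This position therefore tolerates the change of chain without a step beyond the scatter, and compounds 2 and 4 cannot be ordered on this read-out. The change also brings a defined stereocentre, so the contributions of chain length and stereochemistry cannot be separated, and nothing available explains the size of the step.

As far as these compounds go, it remains open how a 1-carboxybutyl chain, or an amide in place of the carboxylic acid, would read at this position. From the compounds shown here alone, the opposite stereocentre of the 1-carboxyethyl group also remains open.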